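Cytotoxicity on Vero cells: one methoxy group becomes two

The compounds below may be only part of what the source reports. "The series", "measured", "known", "first", "only" and "open" are said of these compounds alone.

Measured compounds:
compound 1, `COc1ccc(-c2cc(-c3ccc(C4NC(=O)c5ccccc5N4)cc3)nc(N)n2)cc1`, 124000 nM
compound 2, `CC(C)c1ccc(C(Nc2ccc(C3(C)NC(=O)c4ccccc4N3)cc2)c2nnnn2C2CCCCC2)cc1`, > 400000 nM

Of the compounds shown here, two have been tested in an ADME assay on Vero cells (Chlorocebus sabaeus) for cytotoxicity, read by MTT assay, with a stated time of 72 h; on this read-out lower numbers stand for higher toxicity in this test and higher numbers for lower toxicity in this test. Compound 1 gives 124000 nM in this assay. For compound 2 the read-out of this assay is a limit rather than a number: compound 2 gives > 400000 nM, as recorded in the limit of > 400000 nM in this assay, at which 1 of the 2 values shown sits. Going by the values given here, compound 1 is therefore the only compound with a stated number in this assay, and no step between two measured compounds exists from which a trend could be read.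

Compound 3, `COc1cccc(-c2cc(-c3ccc(C4NC(=O)c5ccccc5N4)cc3)nc(N)n2)c1OC`, has not been measured. It differs from compound 1 in one place: 2,3-dimethoxyphenyl in place of 4-methoxyphenyl on an aromatic carbon. The shared core of compound 1 and compound 3 is otherwise unchanged. Among the compounds with values here, with no measured step available, the size of this change in this assay cannot be anchored on data; the expectation is for no shift beyond the usual scatter, in either direction. Compound 3 is thus expected to give 130000 nM in this assay, between 50000 nM and 350000 nM, a step of a 1.0-fold higher number from compound 1 to compound 3 (0.02 log units; within the scatter) that is expected to stay within the scatter.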

Compound 3, half-maximal cytotoxic concentration: > 400000 nM
Compound 3: no number, only a limit (the forecaster's own chance of this, stated with the estimate: 20%); middle value at least 3.0-fold (0.48 log units) from the limit.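

Going by these compounds alone, the change from 4-methoxyphenyl to 2,3-dimethoxyphenyl on this aromatic carbon, next to the ring nitrogen, gives the first readable step in this assay: an at least 3.2-fold higher number from compound 1 to compound 3 (0.50 log units; beyond the scatter). It shows that the read-out responds to the aryl group at this position, and that this change moves it towards lower toxicity in this test, with the rest of the shared core unchanged. The size of the step has only a lower bound, since compound 3 gives > 400000 nM, which is a limit of the assay and not a number, and the values now gather there: the limit of > 400000 nM in this assay, at which 2 of the 3 values shown sit.

The compounds shown do not separate the effect of the added methoxy group from that of the altered placement, and how far the true value of compound 3 lies beyond its limit stays unknown. Also open, on these data alone, is how a hydroxyl, an amine or a carboxylic acid on this phenyl ring, in place of the methoxy groups, would read in this assay.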